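The compounds below may be only part of what the source reports. "The series", "measured", "known", "first", "only" and "open" are said of these compounds alone.

Compound 1 `CCC1=C(O)c2c(oc(-c3ccc(SC)cc3)cc2=O)C(CC)(CC)C1=O` is measured in a functional assay on KB cells (Homo sapiens) for antiproliferative activity, read by sulforhodamine B assay, with a stated time of 3 days; on this read-out higher numbers stand for an effect only at larger amounts of compound and lower numbers for an effect already at smaller amounts. In this assay compound 1 gives > 52.1 uM, which is a limit of the assay and not a number, so compound 1 stands only at the edge of what the numbers shown can say (the limit of > 52.1 uM in this assay, at which 1 of the 3 values shown sits). Compound 2 `CCC1=C(O)c2c(oc(-c3ccc(F)cc3)cc2=O)C(CC)(CC)C1=O` gives 33 uM in this assay, and compound 3 `CCC1=C(O)c2c(oc(-c3ccc(C)cc3C)cc2=O)C(CC)(CC)C1=O` gives 41.2 uM. The steps from compound 1 are an at least 1.5-fold lower number from compound 1 to compound 2 (0.19 log units; that floor lies within the scatter) and an at least 1.2-fold lower number from compound 1 to compound 3 (0.10 log units; that floor lies within the scatter); between the other two there is a 1.2-fold higher number from compound 2 to compound 3 (0.10 log units; within the scatter).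

Compound 4 `CCC1=C(O)c2c(oc(-c3ccc(O)c(C)c3C)cc2=O)C(CC)(CC)C1=O` differs from compound 1 in one place: 4-hydroxy-2,3-dimethylphenyl in place of 4-(methylsulfanyl)phenyl on an aromatic carbon. The steps from compound 1 to compound 2 and to compound 3 both bear on this change, since each also exchanges the 4-(methylsulfanyl)phenyl for another aryl, and both moved off the limit by only a small margin. For compound 4 a step of about an at least 1.3-fold lower number from compound 1 to compound 4 (0.11 log units; that floor lies within the scatter) is therefore expected, down from the limit but not beyond the scatter with confidence. Compound 4 is estimated at 40 uM, within a range of 18 uM to 90 uM.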

Compound 4, concentration for half-maximal effect: 6.5 uM
Compound 4: middle estimate off by 6.2-fold (0.79 log units), on the high side; the measured number lies below the stated range.
By their numbers in this assay, from the lowest: compound 4; then compounds 2 and 3 (each within the scatter of the next). At a limit, above all of these: compound 1.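

Among the groups shown on this aromatic carbon next to the ring oxygen, only 4-hydroxy-2,3-dimethylphenyl gives a change beyond the scatter in this assay, with a 6.3-fold lower number from compound 3 to compound 4 (0.80 log units; beyond the scatter) and a 5.1-fold lower number from compound 2 to compound 4 (0.71 log units; beyond the scatter). Against the 4-(methylsulfanyl)phenyl group the change is an at least 8.0-fold lower number from compound 1 to compound 4 (0.90 log units; beyond the scatter), and this figure is only a floor. Compound 1 stands at a limit of the assay and not at a number: the limit of > 52.1 uM in this assay, at which 1 of the 4 values shown sits.

The compounds shown leave open whether the hydroxy group, the two methyl groups or their combination accounts for these steps, since no phenyl group carrying the hydroxy alone stands among them. On these data alone, it also remains open whether an amine or a carboxylic acid in place of that hydroxy would give a similar number.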